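The source may hold more compounds than are shown below. What is called first, only, known or untested is meant among the compounds shown, and "the series" means these compounds.

Series notes. Three compounds of the shared core are measured in a functional assay on CHO-K1 cells for antagonist activity at adenosine receptor A1 (Homo sapiens), read by a beta-galactosidase reporter and cAMP accumulation, with stated times of 15 min and 6 h; on this read-out higher numbers stand for weaker inhibition and lower numbers for stronger inhibition: compound 1 `Nc1nc(-c2ncco2)nc2sc(Cc3ccccc3)cc12` gives 310 nM, compound 2 `Nc1nc(-c2cnco2)nc2sc(Cc3ccccc3)cc12` gives 106 nM, and compound 3 `Nc1nc(-c2ccccc2)nc2sc(Cc3ccccc3)cc12` gives 151 nM. Compound 3 sits with compound 2 inside the scatter, a 1.4-fold higher number from compound 2 to compound 3 (0.15 log units; within the scatter), and is set apart only from compound 1, a 2.1-fold lower number from compound 1 to compound 3 (0.31 log units; beyond the scatter). Compound 4 `Nc1nc(-c2cccc(Cl)n2)nc2sc(Cc3ccccc3)cc12` carries the change (6-chloropyridin-2-yl in place of phenyl on an aromatic carbon). Among the compounds with values here, no measured step exchanges phenyl for 6-chloropyridin-2-yl; the nearest steps replace 1,3-oxazol-2-yl or 1,3-oxazol-5-yl at the same carbon with phenyl, a 2.1-fold lower number from compound 1 to compound 3 (0.31 log units; beyond the scatter) and a 1.4-fold higher number from compound 2 to compound 3 (0.15 log units; within the scatter), one modest and one within the scatter. In this assay the expected step is therefore small, without a firm direction, a 1.0-fold lower number from compound 3 to compound 4 (0.00 log units; within the scatter). Compound 4 is estimated at 150 nM, with a range from 50 nM to 450 nM.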

Compound 4, inhibition constant: > 1000 nM
Compound 4: only a limit was reported (the forecaster's own chance of this, stated with the estimate: 3%); at least 6.6-fold (0.82 log units) between middle value and limit.
By their numbers in this assay, from the lowest: compounds 2 and 3 (each within the scatter of the next); then compound 1. At a limit, above all of these: compound 4.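

In this assay, within the data shown here, the carbon between two ring nitrogen atoms proves sensitive to the ring it carries, which the earlier steps, modest at most, did not show: 6-chloropyridin-2-yl in place of phenyl gives an at least 6.6-fold higher number from compound 3 to compound 4 (0.82 log units; beyond the scatter). The same group also gives an at least 9.4-fold higher number from compound 2 to compound 4 (0.97 log units; beyond the scatter) and an at least 3.2-fold higher number from compound 1 to compound 4 (0.50 log units; beyond the scatter), so the change separates compound 4 from all three earlier compounds. The reading for compound 4 is only a limit: the limit of > 1000 nM in this assay, at which 1 of the 4 values shown sits.

The compounds shown leave open whether the ring nitrogen or the chlorine accounts for the change, which a plain pyridin-2-yl or a chlorophenyl on this carbon would separate. As far as these compounds go, how far compound 4 lies past its limit also stays open.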